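The compounds below may be only part of what the source reports. "The series", "measured", "known", "first", "only" and "open" are said of these compounds alone.

Compound 2 `CCNC(=O)c1cc(Oc2ccc(NC(=O)c3cc4cccnc4n(-c4ccc(C(F)(F)F)cc4Cl)c3=O)cc2)ccn1` is the weaker of the two measured compounds in a functional assay on HT-29 cells (Homo sapiens) for antiproliferative activity, read by MTT assay, with a stated time of 72 h (on this read-out higher numbers stand for weaker inhibition and lower numbers for stronger inhibition), where compound 2 gives 4770 nM. For the measured compounds named here, compound 1 `CCNC(=O)c1cc(Oc2ccc(NC(=O)c3cc4cccnc4n(-c4ccc(Br)cc4)c3=O)cc2)ccn1` gives 1160 nM, and the only measured step, a 4.1-fold higher number from compound 1 to compound 2 (0.61 log units; beyond the scatter), came from the change of the group on the aromatic nitrogen. Compound 3 `CCNC(=O)c1cc(Oc2ccc(NC(=O)c3cc4cccnc4n(-c4ccc(F)c(Cl)c4)c3=O)cc2)ccn1` carries 3-chloro-4-fluorophenyl in place of 2-chloro-4-(trifluoromethyl)phenyl on an aromatic nitrogen. Because that step a 4.1-fold higher number from compound 1 to compound 2 (0.61 log units; beyond the scatter) accompanied a move to a bulkier group at this position, the move back to a smaller halogenated ring is expected to reverse part of it. Compound 3 is therefore expected to show a 3.2-fold lower number from compound 2 to compound 3 (0.50 log units; beyond the scatter). Compound 3 is estimated at 1500 nM, with a range from 600 nM to 4000 nM.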

Compound 3, half-maximal inhibitory concentration: 2600 nM
Compound 3: the middle estimate sits 1.7-fold (0.24 log units) below what was measured; measured number inside the range.
By their numbers in this assay, from the lowest: compound 1; then compounds 3 and 2 (each within the scatter of the next).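

In this assay, 3-chloro-4-fluorophenyl on the aromatic nitrogen in place of 2-chloro-4-(trifluoromethyl)phenyl gives a 1.8-fold lower number from compound 2 to compound 3 (0.26 log units; within the scatter) and so the two compounds cannot be told apart, although their rings carry different groups. In place of 4-bromophenyl, the same ring gives a 2.2-fold higher number from compound 1 to compound 3 (0.35 log units; beyond the scatter) and so compound 1 alone stands apart among these three. Nothing measured here explains these results. As far as these compounds go, all three rings carry halogens, so the effect of an amine or a carboxylic acid on the ring remains open.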